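Three Limits and an Anilino Replacement Awaiting Measurement

The compounds below may be only part of what the source reports. "The series", "measured", "known", "first", "only" and "open" are said of these compounds alone.

Of the compounds shown here, three have been tested in a functional assay on L02 cells (Homo sapiens) for inhibition, read by Griess assay, with stated times of 1 h and 24 h; a lower number here means a stronger inhibitor, a higher number a weaker inhibitor. Compound 1 `CCCc1nn(C)c2c(NCc3ccc(F)cc3)nc(/C=C/c3nc(C)c(C)nc3C)nc12` reached only the limit of the assay; in this assay compound 1 gives > 1000000 nM. Compound 2 `Brc1cccc(Nc2nc(/C=C/c3ccccc3)nc3ccsc23)c1` likewise stops at a limit, and in this assay compound 2 gives > 1000000 nM. Compound 3 `COc1cc(/C=C/c2nc(NC3CC3)c3sccc3n2)cc(OC)c1OC` also returns a limit and not a number: in this assay compound 3 gives > 1000000 nM. Compound 3 therefore stands where every measured value stands, at the limit of > 1000000 nM in this assay, at which 3 of the 3 values shown sit, and nothing shown separates it from the other two.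

Compound 4 `COc1ccc(Nc2nc(/C=C/c3cc(OC)c(OC)c(OC)c3)nc3ccsc23)cc1` differs from compound 3 in a single place: 4-methoxyphenyl in place of cyclopropyl on a nitrogen on an aromatic ring. For the measured compounds named here, no step between two measured compounds exists, so the size of this change cannot be read from any neighbouring pair. With every measured value sitting at the limit, the expected step is none beyond the scatter, a number no higher from compound 3 to compound 4 (the limit leaves the size open). Compound 4 is accordingly estimated to give about 1000000 nM in this assay, within a range from 100000 nM to 10000000 nM, and it is expected most likely to be reported once more only as a limit rather than as a number.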

Compound 4, half-maximal inhibitory concentration: 279000 nM
For compound 4 the middle estimate is 3.6-fold (0.55 log units) above the measured one; the range from low to high includes it.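

In this assay, for the compounds shown here, compound 4 gives 279000 nM, the only value shown that is a number and not a limit, so a change of group on this nitrogen on an aromatic ring can bring the read-out within the measurable range. As far as these compounds go, putting 4-methoxyphenyl in place of cyclopropyl at this place gives an at least 3.5-fold lower number from compound 3 to compound 4 (0.55 log units; beyond the scatter), and the full size of this step stays open, as the value at the compound 3 end is only a limit. None of this could be read from the earlier compounds, and most of the set still stands at one place: the limit of > 1000000 nM in this assay, at which 3 of the 4 values shown sit.

Which part of the 4-methoxyphenyl group carries this step remains open, as does whether a plain phenyl or a 4-hydroxyphenyl group on the same nitrogen would give a lower or a higher number than compound 4. Also open, from the compounds shown here alone, is what an amine or a carboxylic acid in place of one of the methoxy groups on the other aromatic ring of compound 4 would do to the read-out.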